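Fluoro on the anilino ring of compound 3

A few compounds are considered here, and "the series" means these few. Any claim that something is new, unique, unknown or untested is made for them only; others in the source may bear on it.

Measured in a functional assay, with a stated time of 150 min, tested at 10 ug/mL; a higher number here means a stronger effect of the compound at the concentration tested, a lower number a weaker effect:
compound 1 `COC(=O)c1c(Nc2ccccc2)sc(C(=O)c2ccc(OC)cc2)c1C`: 18%
compound 2 `COC(=O)c1c(Nc2ccccc2)sc(C(=O)c2ccc(C)cc2)c1C`: 3.16%
compound 3 `COc1ccc(C(=O)c2sc(Nc3ccccc3)c(C(=O)O)c2C)cc1`: 24.7%

Of the three numbers, that of compound 3 is the highest, but a number 6.7 percentage points higher from compound 1 to compound 3 (within the scatter) is within the scatter, so compound 1 and compound 3 cannot be told apart in this assay; only compound 2 stands clearly lower, as a number 14.8 percentage points lower from compound 1 to compound 2 (beyond the scatter) shows.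

Compound 4 `COc1ccc(C(=O)c2sc(Nc3ccc(F)cc3)c(C(=O)O)c2C)cc1` is the next step from compound 3: fluoro in place of hydrogen on an aromatic carbon. Neither measured step touches the anilino ring. Within the data shown here, the one step beyond the scatter, a number 14.8 percentage points lower from compound 1 to compound 2 (beyond the scatter), sits on the other aromatic ring of the shared core, and a number 6.7 percentage points higher from compound 1 to compound 3 (within the scatter) concerns the oxygen of the carbonyl group. Among the measured compounds shown here, the series therefore gives no direct precedent for a change on the anilino ring, and the expectation is a step within the scatter, a number 0.7 percentage points lower from compound 3 to compound 4 (within the scatter), in no firm direction. Compound 4 is estimated at 24% in this assay, with a range from 8% to 40%.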

Compound 4, a percentage reported as activity, at one concentration (the size of the read-out at that concentration, not a potency): 0.98%
Compound 4: middle estimate off by 23 percentage points, on the high side, outside the stated range (below it).
By their numbers in this assay, from the lowest: compounds 4 and 2 (each within the scatter of the next); then compounds 1 and 3 (each within the scatter of the next).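

Among these compounds, the anilino ring, which no earlier step touched, is not a silent place: in this assay the step is a number 23.7 percentage points lower from compound 3 to compound 4 (beyond the scatter). The change is small, a single fluoro para to a large group that adds 1 heavy atom, no ring, no hydrogen-bond donor or acceptor and no net charge, so a minimal edit on this ring is enough to produce a step beyond the scatter. Nothing at hand bears on why this step occurs.

Open, from the compounds shown here alone, is whether the drop belongs to fluoro itself or to any group at this carbon, which chloro, methyl or an amine in the same place would help to separate. Also open, going by these compounds, is whether 4-fluorophenyl behaves the same way with the methyl ester of compound 1 in place of the carboxylic acid, or with fluoro elsewhere on that ring.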